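Swapping Trifluoromethyl for Methoxy on the Aryl Ether

A few compounds are considered here, and "the series" means these few. Any claim that something is new, unique, unknown or untested is made for them only; others in the source may bear on it.

Compound 1 `CC[C@@H]1/C=C(\C)C[C@H](C)C[C@H](OC)[C@H]2O[C@@](O)(C(=O)C(=O)N3CCCC[C@H]3C(=O)O[C@H](/C(C)=C/[C@@H]3CC[C@@H](Oc4ccc(C(F)(F)F)cc4)[C@H](OC)C3)[C@H](C)[C@@H](O)CC1=O)[C@H](C)C[C@@H]2OC` carries a 4-(trifluoromethyl)phenoxy group on its large shared core. Among the compounds with values here, in a functional assay on cells for inhibition, with Murine T-cell line (Mus musculus) as the target (on this read-out higher numbers stand for weaker inhibition and lower numbers for stronger inhibition), compound 1 gives 35.8 nM, the highest of the two numbers measured so far. Its companion, compound 2 `CC[C@@H]1/C=C(\C)C[C@H](C)C[C@H](OC)[C@H]2O[C@@](O)(C(=O)C(=O)N3CCCC[C@H]3C(=O)O[C@H](/C(C)=C/[C@@H]3CC[C@@H](Oc4cccc(O)c4)[C@H](OC)C3)[C@H](C)[C@@H](O)CC1=O)[C@H](C)C[C@@H]2OC`, has 3-hydroxyphenyl in place of 4-(trifluoromethyl)phenyl on an oxygen on a saturated carbon, and in this assay compound 2 gives 1.7 nM; that step, a 21-fold lower number from compound 1 to compound 2 (1.32 log units; beyond the scatter), is the only one measured. Compound 3 `CC[C@@H]1/C=C(\C)C[C@H](C)C[C@H](OC)[C@H]2O[C@@](O)(C(=O)C(=O)N3CCCC[C@H]3C(=O)O[C@H](/C(C)=C/[C@@H]3CC[C@@H](Oc4ccc(OC)cc4)[C@H](OC)C3)[C@H](C)[C@@H](O)CC1=O)[C@H](C)C[C@@H]2OC` differs from compound 1 by methoxy in place of trifluoromethyl on an aromatic carbon, the change sitting on an aromatic carbon of a six-membered aromatic ring of carbon only. Within the data shown here, no measured step repeats this exact swap; the step from compound 1 to compound 2 shows only that replacing trifluoromethyl with an oxygen-bearing group gave a strongly lower number. A smaller step, a 3.0-fold lower number from compound 1 to compound 3 (0.47 log units; beyond the scatter), is therefore expected. For compound 3 the estimate is 12 nM, within 4 nM to 40 nM.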

Compound 3, half-maximal inhibitory concentration: 1.4 nM
Compound 3: the middle estimate sits 8.6-fold (0.93 log units) above what was measured; the measured number lies below the stated range.
By their numbers in this assay, from the lowest: compounds 3 and 2 (each within the scatter of the next); then compound 1.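

The step of a 26-fold lower number from compound 1 to compound 3 (1.41 log units; beyond the scatter) shows that in this assay a change at this one aromatic carbon, para to a large group, is enough to move the number strongly, with the rest of compound 1 left as it is. The earlier step changed both the group and where it sat on the ring, so it could not show this. The step of a 1.2-fold lower number from compound 2 to compound 3 (0.08 log units; within the scatter) lies within the scatter, so 4-methoxyphenyl and 3-hydroxyphenyl cannot be told apart here, and no measurement explains the effect of either group.

Going by these compounds, it remains open whether the lower number follows from the arrival of an oxygen-bearing group or simply from the loss of trifluoromethyl. A methyl group or an amine on the same aromatic carbon would help to separate these two readings.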